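The source may hold more compounds than are shown below. What is called first, only, known or untested is meant among the compounds shown, and "the series" means these compounds.

Within the data shown here, compound 2, `COc1ccc(-c2nc(SCC(=O)c3sc(-c4ccccc4)nc3C)[nH]c(=O)c2C#N)cc1OC`, gives 69.8% in a functional assay on U-87MG ATCC cells for antiproliferative activity against U-87 MG (Homo sapiens), read by MTT assay, with a stated time of 48 h, tested at 10 uM (a lower number here means a stronger effect, a higher number a weaker effect of the compound at the concentration tested), the lowest of the two numbers so far; its nearest neighbour is compound 1, `COc1ccc(-c2nc(SCC(=O)c3sc(-c4ccccc4)nc3C)[nH]c(=O)c2C#N)cc1`, which gives 90.4%. Among the measured compounds shown here, the step of a number 20.6 percentage points lower from compound 1 to compound 2 (beyond the scatter) is the only measured step. Compound 3, `Cc1nc(-c2ccccc2)sc1C(=O)CSc1nc(-c2ccc(Cl)cc2)c(C#N)c(=O)[nH]1`, differs from compound 2 by 4-chlorophenyl in place of 3,4-dimethoxyphenyl on an aromatic carbon. For the measured compounds named here, no measured step involves a 4-chlorophenyl group, so that step bears only loosely on this change. With no closer guide, compound 3 is expected to land between its two predecessors, the estimated step of a number 10.2 percentage points higher from compound 2 to compound 3 (beyond the scatter) lying within the scatter or slightly upward. Compound 3 is thus estimated at 80%, ranging from 55% to 100%.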

Compound 3, a percentage reported as activity, at one concentration (the size of the read-out at that concentration, not a potency): 85.2%
Compound 3: middle estimate off by 5.2 percentage points, on the low side, within the range that was stated.
By their numbers in this assay, from the lowest: compound 2; then compounds 3 and 1 (each within the scatter of the next).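

In this assay, 4-chlorophenyl in place of 3,4-dimethoxyphenyl gives a number 15.4 percentage points higher from compound 2 to compound 3 (beyond the scatter) and so gives up the stronger effect seen with compound 2. Chloro in place of methoxy gives a number 5.2 percentage points lower from compound 1 to compound 3 (within the scatter), so at this position the two singly substituted phenyl groups cannot be told apart, and only the second methoxy of compound 2 stands out. Nothing available here accounts for this difference. Going by these compounds, it remains open whether an amine or a carboxylic acid on this phenyl ring would shift the number, and whether the stronger effect of compound 2 would persist with ethoxy groups in place of its methoxy groups.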